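This account rests on a few compounds, and the source may have more. Where it says the series, first, only, none or still open, it means among the compounds named here.

Working notes on the series.

Compound 1 `NC(=O)c1c(NC(=O)c2ccccc2F)sc2c1CCN(Cc1cccc(Cl)c1)C2` gives 49500 nM in a functional assay on HeLa cells (Homo sapiens) for antiproliferative activity, with a stated time of 24 h; on this read-out higher numbers stand for weaker inhibition and lower numbers for stronger inhibition; compound 2 `NC(=O)c1c(NC(=O)c2ccccc2Cl)sc2c1CCN(C(=S)Nc1ccccc1)C2` gives 46700 nM and compound 3 `NC(=O)c1c(NC(=O)c2ccccc2Cl)sc2c1CCN(C(=S)Nc1ccccc1I)C2` gives 29000 nM, so all three numbers lie within the scatter of one another. Compound 4 `NC(=O)c1c(NC(=O)c2ccccc2F)sc2c1CCN(C(=S)Nc1ccccc1Cl)C2` differs from compound 1 by a group of 10 heavy atoms (7 carbon, 1 nitrogen, 1 sulfur, 1 chlorine; one six-membered aromatic ring of carbon only) in place of a group of 8 heavy atoms (7 carbon, 1 chlorine; one six-membered aromatic ring of carbon only), on an amine nitrogen in a ring. Among the compounds with values here, the only measured step on this part of the core is a 1.6-fold lower number from compound 2 to compound 3 (0.21 log units; within the scatter), an exchange on the aryl of the same thiourea that within the scatter moved nothing. Within the data shown here, no measured pair exchanges the benzyl for the thiourea alone; compound 1 and compound 2 differ in two places and show matching values. The expected step is therefore a 1.1-fold lower number from compound 1 to compound 4 (0.04 log units; within the scatter), none beyond the scatter, and compound 4 is estimated at 45000 nM, between 15000 nM and 130000 nM.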

Compound 4, half-maximal inhibitory concentration: 19400 nM
Compound 4: the middle estimate sits 2.3-fold (0.37 log units) above what was measured; measured number inside the range.
By their numbers in this assay, from the lowest: compounds 4, 3, 2 and 1 (each within the scatter of the next, the first and the last beyond it).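

On the amine nitrogen in a ring, replacing the 3-chlorobenzyl with the group of 10 heavy atoms gives a 2.6-fold lower number from compound 1 to compound 4 (0.41 log units; beyond the scatter), so a change at this position moves the number in this assay beyond the scatter. The earlier step, a 1.6-fold lower number from compound 2 to compound 3 (0.21 log units; within the scatter), stayed within the scatter and did not show this. No available evidence bears on the reason for this step.

Still open, from the compounds shown here alone, is whether the step follows from the thiocarbonyl or from the chlorine on the aromatic ring. A urea or an acetyl on the same nitrogen would also remain to be compared.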